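Chloro in Place of Fluoro: What Compound 4 Might Give

The source may hold more compounds than are shown below. What is called first, only, known or untested is meant among the compounds shown, and "the series" means these compounds.

Compound 1 `O=C(COc1ccc(C(=O)/C=C/c2cccc(Cl)c2)cc1)N[C@H]1CCOC1=O` gives 20900 nM in a functional assay on MCF7 cells (Homo sapiens) for antiproliferative activity, read by MTT assay, with a stated time of 72 h; a lower number here means a stronger inhibitor, a higher number a weaker inhibitor. Compound 2 `O=C(CNc1ccc(F)cc1)N[C@H]1CCOC1=O` gives only a limit of the assay, > 64000 nM. Compound 3 `O=C(COc1ccc(C(=O)/C=C/c2cccc(F)c2)cc1)N[C@H]1CCOC1=O` likewise gives only a limit, > 64000 nM.

Within the data shown here, two of the three measured values sit at the limit (the limit of > 64000 nM in this assay, at which 2 of the 3 values shown sit), so only one step can be counted. Going from compound 3 to compound 1, the change is chloro in place of fluoro on an aromatic carbon, and it produced an at least 3.0-fold lower number from compound 3 to compound 1 (0.48 log units; beyond the scatter).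

Compound 4 `O=C(CNc1ccc(Cl)cc1)N[C@H]1CCOC1=O` has not yet been measured in this assay. It arises from compound 2 by chloro in place of fluoro on an aromatic carbon. This is the same kind of change as that from compound 3 to compound 1, but not the same: there the chloro stands meta to a large group, here it stands para to a large group. The difference between the cores of compound 2 and compound 3 is not broken down here.

Because compound 2 gives only a limit, > 64000 nM, the starting point for compound 4 is itself uncertain. The step from compound 2 to compound 4 is estimated at an at least 1.6-fold lower number from compound 2 to compound 4 (0.20 log units; that floor lies within the scatter), resting on the step seen from compound 3 to compound 1. Compound 4 is therefore expected to give about 40000 nM, between 10000 nM and 64000 nM.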

Compound 4, half-maximal inhibitory concentration: > 64000 nM
Compound 4 ended at the assay's limit; the forecaster's own chance of this, stated with the estimate: 50%; at least 1.6-fold (0.20 log units) between middle value and limit.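

In this assay compound 4 gives > 64000 nM, which is a limit of the assay and not a number. Compound 2 also sits at a limit, so no step between compound 2 and compound 4 can be read: the limit of > 64000 nM in this assay, at which 3 of the 4 values shown sit.

The compounds shown leave open whether chloro in place of fluoro changes the result at all on the core of compound 2.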